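Swapping an Ethoxy for a Phenethyl Group

This account rests on a few compounds, and the source may have more. Where it says the series, first, only, none or still open, it means among the compounds named here.

Three measured compounds share a core and were tested in a functional assay on the whole organism with Mus musculus as the target; on this read-out lower numbers stand for lower potency and higher numbers for higher potency (the scale is a negative logarithm). Compound 1 `CN1CCC(OC(=O)c2ccccc2Oc2ccccc2)CC1` gives 1.24, compound 2 `CCOc1ccccc1C(=O)OC1CCN(C)CC1` gives 1.18, and compound 3 `Cc1ccc(C(=O)OC2CCN(C)CC2)cc1C` gives 1.15. All three numbers lie within the usual scatter of one another, so compound 2 stands in a group of near-equal values rather than apart from them.

The unmeasured compound 4 `CN1CCC(OC(=O)c2ccccc2CCc2ccccc2)CC1` differs from compound 2 at a single place: phenethyl in place of ethoxy on an aromatic carbon. Within the data shown here, the one measured step that touches the same position, ethyl in place of phenyl on an oxygen on an aromatic ring, is a number 0.06 log units lower from compound 1 to compound 2 (within the scatter). Among the measured compounds shown here, that step changed the group at this place without moving the read-out beyond the scatter, and no measured compound carries a phenethyl group here.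

On this basis, the step from compound 2 to compound 4 is expected to be a number 0.02 log units higher from compound 2 to compound 4 (within the scatter), that is, no shift beyond the scatter. Compound 4 is therefore estimated at 1.2, with a range from 0.8 to 1.6.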

Compound 4, logarithm of the reciprocal of the active concentration, log(1/C): 0.86
The estimate for compound 4 lay 0.34 log units above the measured number, and the stated range covers the measured number.
By their numbers in this assay, from the lowest: compounds 4, 3, 2 and 1 (each within the scatter of the next, the first and the last beyond it).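

In this assay the swap from ethoxy to phenethyl gives a number 0.32 log units lower from compound 2 to compound 4 (beyond the scatter) and the swap from phenoxy to phenethyl gives a number 0.38 log units lower from compound 1 to compound 4 (beyond the scatter) so this position can move the read-out beyond the scatter, which the earlier exchange between two groups joined through oxygen did not show. A phenyl ring alone does not set compound 4 apart, since compound 1 also carries one at this place. Nothing shown here explains the lower number.

From the compounds shown here alone, it remains open whether the lower number goes with losing the oxygen on the aromatic ring or with the longer link to the phenyl ring, which a benzyloxy or a phenylamino group here could help to separate. A plain propyl chain at this place would also show whether the phenyl ring of phenethyl matters at all.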